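The source may report more compounds than this note shows. Statements on the series, on what has been measured and on what is new or still open speak of the compounds shown alone.

Measured so far:
compound 1 `CCCCOc1ccc(Oc2ccccc2)cc1` — 5720 nM
compound 2 `CCCCCOc1ccc(Oc2ccccc2)cc1` — 4130 nM

In an assay for inhibition of leukotriene A-4 hydrolase (Homo sapiens), read by spectrophotometry (on this read-out lower numbers stand for stronger inhibition and higher numbers for weaker inhibition), compound 1 gives 5720 nM. Compound 1 has the highest of the two numbers; nearest is compound 2, which gives 4130 nM, a step of a 1.4-fold lower number from compound 1 to compound 2 (0.14 log units; within the scatter). Compound 3 `CCCCOc1ccc(Oc2ccc(O)cc2)cc1` differs from compound 1 by hydroxy in place of hydrogen on an aromatic carbon. For the measured compounds named here, no measured step concerns a change of this kind: the only step measured, a 1.4-fold lower number from compound 1 to compound 2 (0.14 log units; within the scatter), alters the chain instead and stays within the scatter. For compound 3 the expected step from compound 1 is therefore a 1.1-fold lower number from compound 1 to compound 3 (0.06 log units; within the scatter), with none beyond the scatter foreseen. Compound 3 is estimated at 5000 nM, with a range from 1500 nM to 16000 nM.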

Compound 3, half-maximal inhibitory concentration: 5560 nM
For compound 3 the middle estimate is 1.1-fold (0.05 log units) below the measured one; the range from low to high includes it.
By their numbers in this assay, from the lowest: compounds 2, 3 and 1 (each within the scatter of the next).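

In this assay, hydroxy in place of hydrogen on an aromatic carbon, para to a large group, gives a 1.0-fold lower number from compound 1 to compound 3 (0.01 log units; within the scatter). For the compounds shown here, this position therefore takes a hydroxy with no change beyond the scatter, and it is the first change made on an aromatic ring rather than on the chain. No available evidence bears on this result. Still open, going by these compounds, is whether an amine or a carboxylic acid at this position would move the number beyond the scatter. Also open, on these data alone, is whether a longer chain on the core of compound 3 would do so.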